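The source may report more compounds than this note shows. Statements on the series, on what has been measured and on what is new or still open speak of the compounds shown alone.

Compound 1 `NC(=O)C[C@H](NC(=O)CN(c1nc(Cl)nc2c1ncn2C1CCCCO1)C1CC1)C(=O)OCc1ccccc1` gives 35% in a functional assay on the whole organism with Mus musculus as the target, with a stated time of 90 min, at a dose of 25 umol/kg by the oral route; on this read-out higher numbers stand for a stronger effect at the one dose given and lower numbers for a weaker effect. Compound 2 `CC(C)C[C@H](NC(=O)CN(c1nc(Cl)nc2c1ncn2C1CCCCO1)C1CC1)C(=O)OCc1ccccc1` gives 28.2%. Compound 3 `CSCC[C@H](NC(=O)CN(c1nc(Cl)nc2c1ncn2C1CCCCO1)C1CC1)C(=O)OCc1ccccc1` gives 42.7%.

Compound 3 holds the highest of the three numbers, but its separation from compound 1, a number 7.7 percentage points higher from compound 1 to compound 3 (within the scatter), lies within the scatter, so the two cannot be told apart. Within the data shown here, only the step of a number 14.5 percentage points higher from compound 2 to compound 3 (beyond the scatter) is beyond the scatter, and it is modest. Compound 4 `C[C@@H](O)[C@H](NC(=O)CN(c1nc(Cl)nc2c1ncn2C1CCCCO1)C1CC1)C(=O)OCc1ccccc1` differs from compound 3 in one place: 1-hydroxyethyl in place of 2-(methylsulfanyl)ethyl on a saturated chain carbon bound to an amide-type nitrogen and a carbonyl carbon. All three measured steps concern the same saturated chain carbon. The steps of a number 6.8 percentage points lower from compound 1 to compound 2 (within the scatter) and a number 7.7 percentage points higher from compound 1 to compound 3 (within the scatter) were within the scatter, and even the largest, a number 14.5 percentage points higher from compound 2 to compound 3 (beyond the scatter), was modest. The group entering compound 4 carries a hydrogen-bond donor, as does the carbamoyl of compound 1, whose number sits within the scatter of compound 3. Among the measured compounds shown here, no measured step involves a hydroxyl. A step near the scatter is therefore expected in this assay, and compound 4 is estimated at 36%, between 20% and 52%, which means an expected step of a number 6.7 percentage points lower from compound 3 to compound 4 (within the scatter).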

Compound 4, a percentage reported as activity, at one dose (the size of the read-out at that dose, not a potency): 23.4%
Compound 4: middle estimate off by 12.6 percentage points, on the high side; the range from low to high includes it.
By their numbers in this assay, from the lowest: compounds 4, 2, 1 and 3 (each within the scatter of the next, the first and the last beyond it).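

In this assay, among these compounds, 1-hydroxyethyl is the first group at this saturated chain carbon to carry a hydroxyl, and it does not hold the level of 2-(methylsulfanyl)ethyl (a number 19.3 percentage points lower from compound 3 to compound 4 (beyond the scatter)). The hydrogen-bond donor it shares with the carbamoylmethyl group does not make compound 4 match compound 1 (a number 11.6 percentage points lower from compound 1 to compound 4 (beyond the scatter)), whereas the swap from isobutyl cannot be told from the scatter (a number 4.8 percentage points lower from compound 2 to compound 4 (within the scatter)). Nothing measured here explains these steps.

Going by these compounds, how a sec-butyl group, the same branch without the hydroxyl, would compare with 1-hydroxyethyl stays open, as does the other configuration of its stereocentre. On these data alone, the outcome of an amine or a carboxylic acid on this carbon also remains open.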